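A Naphthyl Group Replaces the Aryl Ether

The compounds below may be only part of what the source reports. "The series", "measured", "known", "first", "only" and "open" are said of these compounds alone.

Of the compounds shown here, three sharing one core have been tested in an assay on CHO cells for displacement of a labelled ligand from adenosine receptor A1 (Homo sapiens), read by scintillation counting, with a stated time of 120 min, tested at 10 uM; on this read-out higher numbers stand for more inhibition at the one concentration tested (going by the name of the read-out) and lower numbers for less inhibition. Compound 1 `CC(C)N1CCN(Cc2csc(N)c2C(=O)c2ccc(Cl)cc2)CC1` carries an isopropyl group on an amine nitrogen in a ring; in this assay compound 1 gives 0%. Compound 2 `Nc1scc(CN2CCN(c3cc(Cl)cc(Cl)c3)CC2)c1C(=O)c1ccc(Cl)cc1` carries a 3,5-dichlorophenyl group there, and in this assay compound 2 gives 1%. Compound 3 `Nc1scc(CN2CCN(c3ccc(OC(F)(F)F)cc3)CC2)c1C(=O)c1ccc(Cl)cc1` carries a 4-(trifluoromethoxy)phenyl group, and in this assay compound 3 gives 0%, level with compound 1 and together with it the lowest of the three numbers, though all three lie within the scatter of one another. The steps were small: no change at the digits printed from compound 1 to compound 3 (within the scatter), a number 1 percentage points higher from compound 1 to compound 2 (within the scatter) and a number 1 percentage points lower from compound 2 to compound 3 (within the scatter).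

Compound 4 `Nc1scc(CN2CCN(c3cccc4ccccc34)CC2)c1C(=O)c1ccc(Cl)cc1` differs from compound 3 in one place: naphthalen-1-yl in place of 4-(trifluoromethoxy)phenyl on an amine nitrogen in a ring. The steps from compound 1 and from compound 2 to compound 3 bear directly on this change: they also swap the group on that ring nitrogen, and neither moved the read-out beyond the scatter. The expectation is therefore no step beyond the scatter, no change at the digits printed from compound 3 to compound 4 (within the scatter). For compound 4 the estimate in this assay is 0%, with a range from -5% to 8%.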

Compound 4, a percentage reported as inhibition, at one concentration (the size of the read-out at that concentration, not a potency): 1%
Compound 4: middle estimate off by 1 percentage points, on the low side; the measured number falls inside the stated range.
By their numbers in this assay, from the lowest: compounds 1, 3, 2 and 4 (each within the scatter of the next).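

In this assay, naphthalen-1-yl brings a second aromatic ring and drops the oxygen and fluorine atoms of 4-(trifluoromethoxy)phenyl, yet the result is a number 1 percentage points higher from compound 3 to compound 4 (within the scatter), no change at the digits printed from compound 2 to compound 4 (within the scatter) and a number 1 percentage points higher from compound 1 to compound 4 (within the scatter). This position on the ring nitrogen has now held an isopropyl group, two substituted phenyl groups and a fused pair of aromatic rings, and none of these four compounds separates from the others beyond the scatter. Nothing available explains this flat result.

As far as these compounds go, whether a longer chain ending in a carboxylic acid, or a phenyl group bearing an amine, on that ring nitrogen would lift the number beyond the scatter stays open. So does the effect of replacing the chlorine on the other aromatic ring of the shared core with a methoxy group.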